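Carbamate in place of urea at compound 3

The source may hold more compounds than are shown below. What is called first, only, known or untested is meant among the compounds shown, and "the series" means these compounds.

Among the compounds with values here, compound 3 `CNC(=O)NC[C@@H]1CCCc2cc(S(=O)(=O)c3cccc(F)c3)ccc21` gives 0.398 nM in an assay on isolated protein for displacement of a labelled ligand from 5-hydroxytryptamine receptor 6 (Homo sapiens) (on this read-out lower numbers stand for stronger inhibition and higher numbers for weaker inhibition), the second highest of the three numbers measured so far. Compound 2 `O=S(=O)(c1cccc(F)c1)c1ccc2c(c1)CCC[C@H]2CNCCO` gives 0.126 nM, a 3.2-fold higher number from compound 2 to compound 3 (0.50 log units; beyond the scatter). Compound 1 `O=C(NC[C@@H]1CCCc2cc(S(=O)(=O)c3cccc(F)c3)ccc21)c1ncc[nH]1` gives 15.9 nM, a 40-fold lower number from compound 1 to compound 3 (1.60 log units; beyond the scatter). Compound 4 `COC(=O)NC[C@@H]1CCCc2cc(S(=O)(=O)c3cccc(F)c3)ccc21` differs from compound 3 by methoxy in place of methylamino on a carbonyl carbon. Within the data shown here, no measured step swaps these two groups on the carbonyl carbon: a 40-fold lower number from compound 1 to compound 3 (1.60 log units; beyond the scatter) shows that exchanging the carbonyl substituent can move the number a great deal, while a 3.2-fold higher number from compound 2 to compound 3 (0.50 log units; beyond the scatter) shows only a modest shift when the whole methylcarbamoyl is replaced. The loss of the hydrogen-bond donor is simply counted; its effect is not shown by any pair. Compound 4 is therefore expected to show a modest rise, a 3.8-fold higher number from compound 3 to compound 4 (0.58 log units; beyond the scatter), to an estimated 1.5 nM, with a range of 0.4 nM to 6 nM.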

Compound 4, inhibition constant: 1.59 nM
For compound 4 the middle estimate is 1.1-fold (0.03 log units) below the measured one; low and high end bracket the measured number.
By their numbers in this assay, from the lowest: compound 2; then compound 3; then compound 4; then compound 1.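

In this assay, within the data shown here, methoxy in place of methylamino on a carbonyl carbon gives a 4.0-fold higher number from compound 3 to compound 4 (0.60 log units; beyond the scatter), the first direct reading of this swap, in which a hydrogen-bond donor leaves and a hydrogen-bond acceptor enters. Methoxy also reads lower than 1H-imidazol-2-yl on the carbonyl carbon, with a 10-fold lower number from compound 1 to compound 4 (1.00 log units; beyond the scatter), while methoxycarbonyl reads well above 2-hydroxyethyl on the amine nitrogen, with a 13-fold higher number from compound 2 to compound 4 (1.10 log units; beyond the scatter). No data here bear on the cause of these shifts.

Still open, going by these compounds, is how ethoxy or dimethylamino on the same carbonyl carbon would read, and so whether the number follows the hydrogen-bond donor count or the atom attached to the carbonyl.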